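Swapping the pyridine of compound 3 for an oxime ether

The compounds below may be only part of what the source reports. "The series", "measured", "known", "first", "only" and "open" are said of these compounds alone.

Compound 1 `Cc1nc(-c2ccccc2NCC2=NCCN2)cs1`, compound 2 `Cc1nc(-c2ccccc2NCC2=NCCN2)co1` and compound 3 `c1ccc(-c2ccccc2NCC2=NCCN2)nc1` share one core and differ only in the group on an aromatic carbon. In a functional assay for activation of Alpha-1D adrenergic receptor (Homo sapiens) (a higher number here means that more compound is needed for the effect, a lower number that less compound is needed), compound 1 gives only a limit, < 5020 nM. Compound 2 likewise gives only a limit, < 5020 nM. Going by the values given here, compound 3 gives 41.7 nM, the sole actual number among the three. The other two values are limits (the limit of < 5020 nM in this assay, at which 2 of the 3 values shown sit). The steps a step that the two limits leave unreadable from compound 1 to compound 2, a step that the limit leaves unreadable from compound 1 to compound 3 and a step that the limit leaves unreadable from compound 2 to compound 3 are therefore unreadable and set no size for what follows.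

Compound 4 `CO/N=C(\C)c1ccccc1NCC1=NCCN1` carries a group of 5 heavy atoms (3 carbon, 1 nitrogen, 1 oxygen; no ring) in place of a group of 6 heavy atoms (5 carbon, 1 nitrogen; one six-membered aromatic ring with 1 hetero atom), on an aromatic carbon. Among the compounds with values here, no measured step bears on this change; only the number for compound 3 anchors it. Compound 4 is expected to be weaker, the step of a 7.2-fold higher number from compound 3 to compound 4 (0.86 log units; beyond the scatter) being an estimate only. Compound 4 is estimated at 300 nM in this assay, within 50 nM to 3000 nM.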

Compound 4, half-maximal effective concentration: < 5020 nM
Compound 4 ended at the assay's limit (the forecaster's own chance of this, stated with the estimate: 15%); the middle value does not contradict the limit.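

Compound 4 gives only a limit, so its steps to compound 1, compound 2 and compound 3 cannot be read: the limit of < 5020 nM in this assay, at which 3 of the 4 values shown sit. As far as these compounds go, how the group on compound 4 truly compares with the pyridin-2-yl of compound 3 in this assay stays open.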